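Notes on compound 3 to compound 4

The compounds below may be only part of what the source reports. "The series", "measured", "known", "first", "only" and "open" are said of these compounds alone.

Compound 1 `COc1ccc(Nc2nc(N[C@H]3CC[C@H](N)CC3)nc3c2ncn3CCC(C)C)c(OC)c1`: 5500 nM
Compound 2 `N[C@H]1CC[C@H](Nc2nc(Nc3ccc(O)cc3)c3ncn(C4CCCCC4)c3n2)CC1`: 8900 nM
Compound 3 `CC(C)CCn1cnc2c(Nc3cccc(Cl)c3)nc(N[C@H]3CC[C@H](N)CC3)nc21`: 1500 nM
Compound 4 `CC(C)CCn1cnc2c(Nc3ccc(O)cc3)nc(N[C@H]3CC[C@H](N)CC3)nc21`: not yet measured

In a functional assay on K562 cells (Homo sapiens) for inhibition, read by fluorescence, with a stated time of 72 h (on this read-out higher numbers stand for weaker inhibition of growth and lower numbers for stronger inhibition of growth), compound 3 stands lowest of the three measured compounds, at 1500 nM. The next change leads to compound 4: 4-hydroxyphenyl in place of 3-chlorophenyl on a nitrogen on an aromatic ring. In words, this is 4-hydroxyphenyl in place of 3-chlorophenyl on a nitrogen on an aromatic ring.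

Among the measured compounds shown here, one measured step bears directly on this place: a 3.7-fold lower number from compound 1 to compound 3 (0.56 log units; beyond the scatter). It shows that the group on this nitrogen can move the number by a modest amount. Compound 2 carries the same 4-hydroxyphenyl group and gives 8900 nM, but it also differs from compound 4 elsewhere, so it is only a loose guide. For the measured compounds named here, no measured pair isolates this exchange.

A modest move towards a higher number in this assay is therefore expected, beyond the scatter. The expected change is a 2.7-fold higher number from compound 3 to compound 4 (0.43 log units; beyond the scatter). For compound 4 the estimate is 4000 nM, with an expected range of 1600 nM to 10000 nM.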

Compound 4, concentration for 50% growth inhibition: 4600 nM
Beside the measured number, compound 4's estimate is 1.2-fold (0.06 log units) below it; the range from low to high includes it.
By their numbers in this assay, from the lowest: compound 3; then compounds 4, 1 and 2 (each within the scatter of the next).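

In this assay, this exchange on the nitrogen now stands as a single change (a 3.1-fold higher number from compound 3 to compound 4 (0.49 log units; beyond the scatter)), and of the groups shown there, 3-chlorophenyl goes with the lowest number. The 4-hydroxyphenyl and 2,4-dimethoxyphenyl groups are not separated on the same isopentyl compounds (a 1.2-fold lower number from compound 1 to compound 4 (0.08 log units; within the scatter)), and isopentyl in place of cyclohexyl on the aromatic nitrogen also stays within the scatter (a 1.9-fold lower number from compound 2 to compound 4 (0.29 log units; within the scatter)). No measurement on hand accounts for the step between the 3-chlorophenyl and 4-hydroxyphenyl compounds.

The exchange alters both the substituent and its printed ring number, so the compounds shown do not separate these two changes. On these data alone, how 4-chlorophenyl or 3-hydroxyphenyl would compare on this nitrogen remains open, as does the outcome with an aminophenyl or carboxyphenyl group.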